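A few compounds are considered here, and "the series" means these few. Any claim that something is new, unique, unknown or untested is made for them only; others in the source may bear on it.

Going by the values given here, in a functional assay on FaDu cells (Homo sapiens) for cytotoxicity, read by MTT assay, with a stated time of 72 h (a lower number here means that less compound is tolerated, a higher number that more compound is tolerated), compound 2 `CCn1cc(C(=O)C(=O)Nc2ccnc(OC)c2)c2ccccc21` gives 4180 nM, the highest number among the compounds measured so far: compound 1 `COCCn1cc(C(=O)C(=O)Nc2ccc(OC(F)(F)F)cc2)c2ccccc21` gives 487 nM, and compound 3 `CCn1cc(C(=O)C(=O)Nc2ccc(OC)nc2)c2ccccc21` gives 219 nM. Among the compounds with values here, the only measured step between compounds that differ in a single place runs a 19-fold lower number from compound 2 to compound 3 (1.28 log units; beyond the scatter), but it alters the ring attached to the amide nitrogen and leaves the chain on the shared core untouched, so it says nothing about the change now in view. Compound 4 `COCCn1cc(C(=O)C(=O)Nc2ccnc(OC)c2)c2ccccc21` differs from compound 2 by methoxy in place of hydrogen on a saturated chain carbon, two bonds along the chain from an aromatic nitrogen. Compound 1 already carries the 2-methoxyethyl chain, yet it also bears a different ring on the amide nitrogen, so the values of compound 1 and compound 2 show only that the two differ by more than the scatter, without telling which of the two changes is responsible. Within the data shown here, no measured step therefore bears directly on the change from compound 2 to compound 4, and a step no larger than the scatter in this assay is expected, with the number staying close to where compound 2 stands. Compound 4 is expected to give 3500 nM, with a range from 1400 nM to 9000 nM. For compound 4 this expectation amounts to a 1.2-fold lower number from compound 2 to compound 4 (0.08 log units; within the scatter).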

Compound 4, concentration lethal to 50% of the cells: 235 nM
The estimate for compound 4 lay 15-fold (1.17 log units) above the measured number; the measured number lies below the stated range.
By their numbers in this assay, from the lowest: compounds 3 and 4 (each within the scatter of the next); then compound 1; then compound 2.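

In this assay the change from ethyl to 2-methoxyethyl on the aromatic nitrogen of the shared core brings an 18-fold lower number from compound 2 to compound 4 (1.25 log units; beyond the scatter) while the ring on the amide nitrogen stays the same. Going by these compounds alone, earlier, the only single change on record was to that ring, with a 19-fold lower number from compound 2 to compound 3 (1.28 log units; beyond the scatter) as its step, so this result adds a second place where one change moves the number well beyond the scatter, here towards less compound being tolerated. Nothing measured here gives a reason for this step.

The compounds shown leave open whether adding methoxy to the chain would bring a similar step with 6-methoxypyridin-3-yl on the amide nitrogen, where compound 3 already gives 219 nM with the ethyl chain. They also leave open whether the oxygen of the methoxy group matters or chain length alone is enough, which a plain propyl or butyl chain could tell, and how a 2-aminoethyl chain or a longer 3-methoxypropyl chain would compare.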